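The source may hold more compounds than are shown below. What is called first, only, known or untested is meant among the compounds shown, and "the series" means these compounds.

Compound 1, `COc1ccc([C@@H]2CC(=O)c3c(O)cc(OCc4cn(Cc5ccccc5F)nn4)cc3O2)cc1O`, is one of two compounds examined in a functional assay on RAW264.7 cells (Mus musculus) for inhibition, read by Griess assay, with stated times of 2 h and 24 h; on this read-out lower numbers stand for stronger inhibition and higher numbers for weaker inhibition. In this assay compound 1 gives 7320 nM, which is the higher of the two numbers recorded. The other compound, compound 2, `COc1ccc([C@@H]2C/C(=N\O)c3c(O)cc(OCc4cn(-c5ccccc5)nn4)cc3O2)cc1O`, carries a phenyl directly on the aromatic nitrogen and an oxime instead of the carbonyl on the shared core; in this assay compound 2 gives 6130 nM. The two values lie within the scatter of each other, so nothing can be said about an order between compound 1 and compound 2.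

Compound 3, `COc1ccc([C@@H]2CC(=O)c3c(O)cc(OCc4cn(CCCO)nn4)cc3O2)cc1O`, has not yet been measured in this assay. It differs from compound 1 by 2-hydroxyethyl in place of 2-fluorophenyl on a saturated chain carbon bound to an aromatic nitrogen. The change removes the 2-fluorophenyl, with its one six-membered aromatic ring of carbon only, and brings in a short chain with one hydrogen-bond donor and one hydrogen-bond acceptor. Among the measured compounds shown here, no measured pair among the compounds examined isolates this change, so there is nothing to anchor a direction. Compound 3 is therefore expected to show a step of a 1.2-fold higher number from compound 1 to compound 3 (0.09 log units; within the scatter) from compound 1, likely not beyond the scatter. Compound 3 is estimated at 9000 nM, within a range from 3000 nM to 27000 nM.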

Compound 3, half-maximal inhibitory concentration: 16700 nM
Beside the measured number, compound 3's estimate is 1.9-fold (0.27 log units) below it; low and high end bracket the measured number.
By their numbers in this assay, from the lowest: compounds 2 and 1 (each within the scatter of the next); then compound 3.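

In this assay, 2-hydroxyethyl in place of 2-fluorophenyl on a saturated chain carbon bound to an aromatic nitrogen gives a 2.3-fold higher number from compound 1 to compound 3 (0.36 log units; beyond the scatter). Among the compounds shown here, this is the first comparison of compounds differing in one place, and it shows that this position is not indifferent to what it carries: the change, read one bond further out as 2-fluorobenzyl to 3-hydroxypropyl, moves the read-out beyond the scatter towards weaker inhibition, though the step is modest. Nothing at hand bears on why the number rises, so the step stands as an observation only.

The change removes the six-membered aromatic ring of carbon only and brings in the hydroxyl in one move, so the compounds shown leave open which of the two goes with the weaker inhibition, a question that a plain propyl chain or an unsubstituted benzyl group would address. Also open, going by these compounds, is how an amine, a carboxylic acid or a longer chain would fare at this position, and whether the same step would appear on the oxime form of the shared core.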